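The compounds below may be only part of what the source reports. "The series", "measured", "known", "first", "only" and "open" are said of these compounds alone.

Working notes on the series. Compound 1 `O=C(Nn1c(-c2cccc([N+](=O)[O-])c2)nc2c(-c3ccco3)n[nH]c2c1=O)c1cccnc1` is the reference point; in a functional assay on A549 cells (Homo sapiens) for cytotoxicity, read by sulforhodamine B assay, with a stated time of 2 days, tested at 100 uM (a higher number here means more inhibition at the concentration tested (going by the name of the read-out), a lower number less inhibition), compound 1 gives 1.51%. Compound 2 `COc1cccc(-c2nc3c(-c4ccco4)n[nH]c3c(=O)n2NC(=O)c2cccnc2)c1` differs from compound 1 by one change, (methoxy in place of nitro on an aromatic carbon), and in this assay compound 2 gives 14.9%, so that a number 13.4 percentage points higher from compound 1 to compound 2 (beyond the scatter). Compound 3 `O=C(Nn1c(-c2cccc([N+](=O)[O-])c2)nc2c(-c3ccc(Cl)cc3)n[nH]c2c1=O)c1ccccc1` has a core that differs from that of compound 1; the difference between the two cores is not broken down here. In this assay compound 3 gives 88.6%, the highest number among the three measured compounds. Compound 4 `COc1cccc(-c2nc3c(-c4ccc(Cl)cc4)n[nH]c3c(=O)n2NC(=O)c2ccccc2)c1` is not yet measured and is related to compound 3 by the same change, (methoxy in place of nitro on an aromatic carbon), that relates compound 1 to compound 2; the change occurs twice across the set, and the surroundings of the place are described in identical words in both cases. The earlier step was modest, and compound 3 already stands near the top of the scale, leaving little room upward. The step from compound 3 to compound 4 is expected to be a number 0.4 percentage points higher from compound 3 to compound 4 (within the scatter). For compound 4 in this assay the estimate is 89%, with a range from 65% to 99%. This expectation rests on compound 3 giving 88.6% in this assay and on the step of a number 13.4 percentage points higher from compound 1 to compound 2 (beyond the scatter).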

Compound 4, a percentage reported as inhibition, at one concentration (the size of the read-out at that concentration, not a potency): 81.8%
The estimate for compound 4 lay 7.2 percentage points above the measured number; measured number inside the range.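

In this assay, the change from 3-nitrophenyl to 3-methoxyphenyl on the core of compound 3 gives a number 6.8 percentage points lower from compound 3 to compound 4 (within the scatter), and the same change does not give the same result on the two cores: the same change on two cores in this assay, a number 13.4 percentage points higher (beyond the scatter) from compound 1 to compound 2 and a number 6.8 percentage points lower (within the scatter) from compound 3 to compound 4, 20.2 percentage points apart, beyond the scatter of two such steps For this series, then, the step measured on the core of compound 1 cannot be carried over as a fixed increment to the core of compound 3, and a step read on one core is a poor guide to the other. This does not show which part of the core difference is responsible, since the two cores are not broken down here, and two pairs give no general rule for how the change behaves on other cores.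

Going by these compounds, it remains open whether an amine or a carboxylic acid in the same place on the six-membered ring would follow the pattern of the core of compound 1 or that of compound 3. On these data alone, the size of the nitro to methoxy step on a third core also remains open.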